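From a Piperidinyl Amide Ether to a Small Carbamoyl

A few compounds are considered here, and "the series" means these few. Any claim that something is new, unique, unknown or untested is made for them only; others in the source may bear on it.

Of the compounds shown here, three share one core and have been measured in an assay on isolated protein (strain Sprague-Dawley) for inhibition of Amine oxidase [flavin-containing] A (Rattus norvegicus), read by spectrophotometry, with a stated time of 5 min, tested at 10 uM; on this read-out higher numbers stand for more inhibition at the one concentration tested (going by the name of the read-out) and lower numbers for less inhibition. Compound 1 `O=c1cc(O)c2ccc(OCc3cccc(Br)c3)cc2o1` gives 0%. Compound 2 `COc1cc(=O)oc2cc(OCc3cccc(Br)c3)ccc12` gives 27%. Compound 3 `O=C(COc1cc(=O)oc2cc(OCc3cccc(Cl)c3)ccc12)N1CCCCC1` gives 9%. Compound 3 thus stands second highest of the three; its nearest neighbour is compound 1, whose number is lower but within the scatter, and its furthest is compound 2, whose number is higher beyond the scatter.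

Compound 4 `NC(=O)c1cc(=O)oc2cc(OCc3cccc(Cl)c3)ccc12` differs from compound 3 in one place: carbamoyl in place of ((piperidin-1-yl)carbonyl)methoxy on an aromatic carbon.

For the measured compounds named here, the only measured step is a number 27 percentage points higher from compound 1 to compound 2 (beyond the scatter), a change at a different spot on the core, and none of the measured steps trades a large side chain for a small one at the carbon in question. With no direct guidance, and the three numbers all lying low, the step from compound 3 to compound 4 is expected to stay within the scatter, as a number 3 percentage points higher from compound 3 to compound 4 (within the scatter). Compound 4 is therefore estimated at 12%, within a range from 0% to 35%.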

Compound 4, a percentage reported as inhibition, at one concentration (the size of the read-out at that concentration, not a potency): 14%
Compound 4: middle estimate off by 2 percentage points, on the low side; the measured number falls inside the stated range.
By their numbers in this assay, from the lowest: compounds 1, 3 and 4 (each within the scatter of the next, the first and the last beyond it); then compound 2.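

Moving to this aromatic carbon opposite the ring oxygen, replacing ((piperidin-1-yl)carbonyl)methoxy with carbamoyl removes the six-membered non-aromatic ring, leaves a far smaller group and adds a hydrogen-bond donor, yet this assay shows a number 5 percentage points higher from compound 3 to compound 4 (within the scatter). This large change in the group at this position therefore produces no clear difference at the one concentration tested, so the two groups cannot be told apart on this read-out. No measured evidence bears on why this is so.

On these data alone, whether a carboxylic acid, an amine or a longer chain on this carbon would give a number clearly different from these two remains open. Also open, as far as these compounds go, is how carbamoyl compares with the methoxy group of compound 2, which differs from compound 4 in more than one place.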